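Oxetanyl Capping of the Amine Terminus in a Quinoline Series

The source may hold more compounds than are shown below. What is called first, only, known or untested is meant among the compounds shown, and "the series" means these compounds.

Measured compounds:
- compound 1 `N=C(N)NCCNc1cc(N2CCc3ccccc3C2)nc2ccccc12` — > 100000 nM
- compound 2 `Cc1ccc2nc(N3CCCc4ccccc4C3)cc(NCCN)c2c1` — 9400 nM
- compound 3 `Cc1ccc2nc(N3CCCc4ccc(F)cc4C3)cc(NCCN)c2c1` — > 3200 nM

The shared core carries a saturated bicyclic amine on one side and an aminoethyl chain on the other. In an ADME assay on HEp-2 cells (Homo sapiens) for cytotoxicity, read by CCK-8 assay, with a stated time of 5 days (a higher number here means that more compound is tolerated, a lower number that less compound is tolerated), compound 2 gives 9400 nM. For compound 1 only a limit is known, > 100000 nM, and this is a limit of the assay rather than a number (the limit of > 100000 nM in this assay, at which 1 of the 3 values shown sits). Compound 3 likewise is known only as a limit, > 3200 nM, again a limit and not a number (the limit of > 3200 nM in this assay, at which 1 of the 3 values shown sits). Among the measured compounds shown here, the single one-place step recorded, a step that the limit leaves unreadable from compound 2 to compound 3, is therefore unreadable in size, so the measured steps give no scale for what a substituent change can do here.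

Compound 4 `Cc1ccc2nc(N3CCCc4ccc(F)cc4C3)cc(NCCNC3COC3)c2c1` differs from compound 3 by oxetan-3-yl in place of hydrogen on an amine nitrogen. For the measured compounds named here, no measured step bears on a change at the amine nitrogen. Because compound 3 stands at a limit > 3200 nM, compound 4 is expected to remain tolerated, with an estimated step that the limit leaves unreadable from compound 3 to compound 4. Compound 4 is estimated at 10000 nM, within 3000 nM to 40000 nM.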

Compound 4, half-maximal cytotoxic concentration: > 100000 nM
Compound 4 ended at the assay's limit; the forecaster's own chance of this, stated with the estimate: 50%; middle value at least 10-fold (1.00 log units) away from the limit.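

In this assay compound 4 gives > 100000 nM, a limit of the assay and not a number. Compound 3 is likewise known only as a limit, and the step between compound 3 and compound 4 cannot be read. The compounds shown leave open how large a change oxetan-3-yl in place of hydrogen on an amine nitrogen produces.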